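Changing the Arm on a Shared Core: Hydrazone to Benzimidazole

A few compounds are considered here, and "the series" means these few. Any claim that something is new, unique, unknown or untested is made for them only; others in the source may bear on it.

Of the compounds shown here, three built on one shared core have been tested in a functional assay, read by spectrophotometry, with a stated time of 5 min; a higher number here means a weaker inhibitor, a lower number a stronger inhibitor. Compound 1 `O=c1cc(/C=N\c2ccccc2O)c2c(OCc3ccccc3)cc(OCc3ccccc3)cc2o1` gives 33100 nM. Compound 2 `O=c1cc(/C=N\Nc2ccc([N+](=O)[O-])cc2)c2ccc(OCc3ccccc3)cc2o1` returns only a limit, > 2000000 nM, recorded as the limit of > 2000000 nM in this assay, at which 1 of the 3 values shown sits. Compound 3 `O=c1cc(/C=N\Nc2ccccc2)c2ccc(OCc3ccccc3)cc2o1` gives 416000 nM in this assay, the higher of the two plain numbers, with compound 1 the nearest and lower by a margin beyond the scatter. For the measured compounds named here, the single step that can be followed, an at least 4.8-fold lower number from compound 2 to compound 3 (0.68 log units; beyond the scatter), shows that taking the nitro group off the outer ring lowers the number.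

Compound 4 `O=c1cc(-c2nc3ccccc3[nH]2)c2ccc(OCc3ccccc3)cc2o1` differs from compound 3 in one place: a group of 9 heavy atoms (7 carbon, 2 nitrogen; one five-membered aromatic ring with 2 hetero atoms, one six-membered aromatic ring of carbon only) in place of a group of 9 heavy atoms (7 carbon, 2 nitrogen; one six-membered aromatic ring of carbon only), on an aromatic carbon. Going by the values given here, no measured step covers a change of this kind; the only step seen concerned a nitro group on a separate ring and was at least modest. There is thus no basis for expecting a step beyond the scatter in either direction. Compound 4 is expected to land near compound 3, at about 300000 nM. Given the single point of comparison, the expected span for compound 4 runs from 40000 nM to 1500000 nM. The expected step of a 1.4-fold lower number from compound 3 to compound 4 (0.14 log units; within the scatter) therefore stays close to no change.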

Compound 4, half-maximal inhibitory concentration: 146000 nM
Beside the measured number, compound 4's estimate is 2.1-fold (0.31 log units) above it; the range from low to high includes it.
By their numbers in this assay, from the lowest: compound 1; then compound 4; then compound 3. At a limit, above all of these: compound 2.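

The earlier step altered only the outer ring of the arm, whereas this one replaces the whole arm on the aromatic carbon opposite the ring oxygen, with 1H-benzimidazol-2-yl taking the place of the hydrazone arm. The two groups match in their counts of heavy atoms, carbon and nitrogen, yet this assay records a 2.8-fold lower number from compound 3 to compound 4 (0.45 log units; beyond the scatter), so this position tolerates a new arrangement of much the same atoms, and the change gives a modestly stronger inhibitor rather than a weaker one. Nothing measured here explains why the number falls, and the one available supporting fact concerns a different compound.

Compound 4, at 146000 nM, leaves open whether an amine or a carboxylic acid on the benzimidazole's six-membered ring would lower the number further. On these data alone, it also remains open whether a single five-membered aromatic ring with 2 hetero atoms, without the fused six-membered ring, would give a similar step at this position.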